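A few compounds are considered here, and "the series" means these few. Any claim that something is new, unique, unknown or untested is made for them only; others in the source may bear on it.

Compound 1 `O=S(=O)(c1ccccc1)c1c(OCCCCCCO)no[n+]1[O-]` carries a 4-hydroxybutyl end on its chain and in a functional assay on HeLa cells (Homo sapiens) for inhibition, read by MTT assay, with a stated time of 48 h (on this read-out higher numbers stand for weaker inhibition and lower numbers for stronger inhibition), compound 1 gives "not determined" (no result reported), so it stands nowhere on the numbers. The step to compound 4 `O=C(COCCOc1no[n+]([O-])c1S(=O)(=O)c1ccccc1)NO` is (hydroxycarbamoyl)methoxy in place of 4-hydroxybutyl on a saturated chain carbon, two bonds along the chain from an oxygen on an aromatic ring. Within the data shown here, no measured step bears on this change directly. The nearest information comes from the two hydroxamic acids of the series: compound 2 `O=C(CCCCOc1no[n+]([O-])c1S(=O)(=O)c1ccccc1)NO` gives 3650 nM in this assay, and compound 3 `O=C(CCCCCCOc1no[n+]([O-])c1S(=O)(=O)c1ccccc1)NO` gives 4090 nM. Among the measured compounds shown here, the only measured step, a 1.1-fold higher number from compound 2 to compound 3 (0.05 log units; within the scatter), shows that lengthening the chain between the aromatic oxygen and the hydroxycarbamoyl group leaves this assay unchanged beyond the scatter. Compound 4, with its shorter ether-containing chain to the same terminal group, is therefore expected near those two values: estimated at 3800 nM, with a range from 1500 nM to 10000 nM.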

Compound 4, half-maximal inhibitory concentration: 6690 nM
The estimate for compound 4 lay 1.8-fold (0.25 log units) below the measured number; the measured number falls inside the stated range.
By their numbers in this assay, from the lowest: compounds 2, 3 and 4 (each within the scatter of the next).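

In this assay, (hydroxycarbamoyl)methoxy at this position stays within the scatter of both other hydroxamic acids, with a 1.6-fold higher number from compound 3 to compound 4 (0.21 log units; within the scatter) and a 1.8-fold higher number from compound 2 to compound 4 (0.26 log units; within the scatter). An ether oxygen in the chain therefore does not separate compound 4 from compound 2 or compound 3 on this read-out. Nothing available explains this result. Still open, on these data alone, is whether a carboxylic acid or an amine in place of the hydroxycarbamoyl end would hold the number within the scatter. As far as these compounds go, a longer chain carrying the ether oxygen also remains open.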